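A Benzyl Group Enters the Saturated Ring of Compound 2

The source may report more compounds than this note shows. Statements on the series, on what has been measured and on what is new or still open speak of the compounds shown alone.

Compound 1, `NS(=O)(=O)Oc1ccc2c(c1)CN(C(=O)c1ccc(N3CCC(N4CCCCC4)CC3)cc1)CC2`: 53.7%
Compound 2, `NS(=O)(=O)Oc1ccc2c(c1)CN(C(=O)c1ccc(N3CCCCC3)cc1)CC2`: 38.3%

In an assay on HEK293 cells for inhibition of Steryl-sulfatase (Homo sapiens), tested at 1 uM (on this read-out higher numbers stand for a stronger effect at the one concentration tested and lower numbers for a weaker effect), compound 2 gives 38.3%, the lower of the two numbers measured, while compound 1 gives 53.7%. Compound 3, `NS(=O)(=O)Oc1ccc2c(c1)CN(C(=O)c1ccc(N3CCC(Cc4ccccc4)CC3)cc1)CC2`, differs from compound 2 in one place: benzyl in place of hydrogen on a saturated ring carbon. Within the data shown here, only one measured step bears on that place, a number 15.4 percentage points lower from compound 1 to compound 2 (beyond the scatter), and it shows that a group leaving that saturated ring carbon cost a modest amount of inhibition. Read the other way, a group entering there is expected to bring a modest gain, a number 11.7 percentage points higher from compound 2 to compound 3 (beyond the scatter). Compound 3 is thus estimated at 50%, in a range from 30% to 70%.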

Compound 3, a percentage reported as inhibition, at one concentration (the size of the read-out at that concentration, not a potency): 81.3%
Beside the measured number, compound 3's estimate is 31.3 percentage points below it; the measured number lies above the stated range.
By their numbers in this assay, from the lowest: compound 2; then compound 1; then compound 3.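

In this assay, benzyl on this saturated ring carbon brings a large gain (a number 43 percentage points higher from compound 2 to compound 3 (beyond the scatter)) and also exceeds piperidin-1-yl at the same place (a number 27.6 percentage points higher from compound 1 to compound 3 (beyond the scatter)). The size of the gain at this position therefore depends on which group enters, not merely on a group being present there. Nothing available explains why benzyl does better. From the compounds shown here alone, whether phenethyl, a longer chain, or directly attached phenyl would match benzyl remains open, as does the effect of an amine or carboxylic acid on its aromatic ring. Each compound has a reading at only one concentration, and these readings show only a stronger or weaker effect at that concentration.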